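Nitro for chloro on the aryl ether of compound 1

The compounds below may be only part of what the source reports. "The series", "measured", "known", "first", "only" and "open" are said of these compounds alone.

Measured so far:
compound 1 `Clc1ccc(OC(CCn2ccnc2)c2ccccc2)cc1`: 84900 nM
compound 2 `Cc1ccc(C(CCn2ccnc2)Oc2ccc(Cl)cc2Cl)cc1`: 40000 nM

In a functional assay on U-937 cells (Homo sapiens) for cytotoxicity (a lower number here means that less compound is tolerated, a higher number that more compound is tolerated), compound 1 gives the higher of the two numbers; the value of compound 2 sits below it by more than the usual scatter. Among the measured compounds shown here, the two measured compounds differ in more than one place, so no single-point step is available to calibrate the change now under consideration.

Compound 3 `O=[N+]([O-])c1ccc(OC(CCn2ccnc2)c2ccccc2)cc1` carries nitro in place of chloro on an aromatic carbon. Neither measured compound informs on an aromatic nitro group, so the expectation rests on compound 1 alone. The step expected in this assay a 1.1-fold lower number from compound 1 to compound 3 (0.03 log units; within the scatter) is estimated to fall within the usual scatter, with no direction favored. Compound 3 is therefore expected to give about 80000 nM, with an estimated range from 30000 nM to 200000 nM.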

Compound 3, half-maximal cytotoxic concentration: 97200 nM
Compound 3: the middle estimate sits 1.2-fold (0.08 log units) below what was measured, and the stated range covers the measured number.
By their numbers in this assay, from the lowest: compound 2; then compounds 1 and 3 (each within the scatter of the next).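

In this assay, among the compounds shown here, nitro in place of chloro on an aromatic carbon, para to a large group, provides the first single-point step (a 1.1-fold higher number from compound 1 to compound 3 (0.06 log units; within the scatter)), so compound 1 and compound 3 cannot be separated at this position. Going from one heavy atom and no hydrogen-bond acceptors in chloro to three heavy atoms and two hydrogen-bond acceptors in nitro therefore does not move the read-out beyond the scatter. No measurement on hand explains this outcome.

On these data alone, whether an amine, a carboxylic acid or a methoxy group at this position would also stay within the scatter remains open. Also open, as far as these compounds go, is which difference separates compound 2 from compound 1, as these two compounds differ in more than one place.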